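Inverting Part of the Stereochemistry of Compound 2

The source may report more compounds than this note shows. Statements on the series, on what has been measured and on what is new or still open speak of the compounds shown alone.

Measured in a functional assay on A549 cells (Homo sapiens) for cytotoxicity; a lower number here means a stronger inhibitor, a higher number a weaker inhibitor:
Compound 1 `CCCCCCCCCCCCCC[C@H]1N[C@H](CO)[C@H]1O`: > 2 ug/mL
Compound 2 `CCCCCCCCCCCCCC[C@@H]1N[C@@H](CO)[C@@H]1O`: 0.34 ug/mL

Compound 1 is reported only as a limit, > 2 ug/mL. Among the measured compounds shown here, compound 2 gives 0.34 ug/mL, the only true number so far. Compound 3 `CCCCCCCCCCCCCC[C@@H]1N[C@H](CO)[C@H]1O` alters configuration alone: the two compounds have the same atoms and bonds and differ only in configuration as drawn: 2 of 3 stereo elements differ; a stereocentre at a saturated ring carbon is drawn S in compound 2 and R in compound 3; a stereocentre at a saturated ring carbon is drawn R in compound 2 and S in compound 3. For the measured compounds named here, the one measured step that bears on this is an at least 5.8-fold lower number from compound 1 to compound 2 (0.76 log units; beyond the scatter), with the fact that compounds 1 and 2 differ only in the configuration as drawn. That step inverted every stereocentre, so compound 3, with only some inverted from compound 2, is expected to give a higher number, by an uncertain amount. The expected change is a 2.9-fold higher number from compound 2 to compound 3 (0.47 log units; beyond the scatter). Compound 3 is estimated at 1 ug/mL, with an expected range of 0.3 ug/mL to 4 ug/mL.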

Compound 3, half-maximal inhibitory concentration: 1.97 ug/mL
Compound 3: the middle estimate sits 2.0-fold (0.29 log units) below what was measured; measured number inside the range.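

Inverting only two of the three stereocentres, with atoms and bonds unchanged, gives a 5.8-fold higher number from compound 2 to compound 3 (0.76 log units; beyond the scatter) in this assay, so a partial inversion is enough to weaken the compound, and a full mirror image is not needed. Compound 1 is reported only as a limit, > 2 ug/mL. From the compounds shown here alone, the remaining step is an at least 1.0-fold lower number from compound 1 to compound 3 (0.00 log units; that floor lies within the scatter), so the effect of the third stereocentre stays unknown.

Going by these compounds, the two inverted stereocentres changed together here, so their separate contributions remain open. Also open, on these data alone, is whether a carboxylic acid or a longer chain on the shared core would show the same sensitivity to configuration.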